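Methoxy for Chloro on a Weak Cytotoxic Pair

A few compounds are considered here, and "the series" means these few. Any claim that something is new, unique, unknown or untested is made for them only; others in the source may bear on it.

Two measured compounds set the scene. Compound 1 `COc1ccc(-n2ccc(=O)c(C(=O)Nc3ccc(Oc4ccnc5[nH]ccc45)cc3)n2)cc1`, tested in a functional assay on A549 cells (Homo sapiens) for cytotoxicity, read by MTT assay, with a stated time of 72 h (a lower number here means a stronger inhibitor, a higher number a weaker inhibitor), gives 53100 nM, a weak result. Compound 2 `Cn1ccc2c(Oc3ccc(NC(=O)c4nn(-c5ccc(Cl)cc5)ccc4=O)cc3)ccnc21` gives only > 60000 nM in this assay, which is a limit of the assay rather than a number. This is the case described by the limit of > 60000 nM in this assay, at which 1 of the 2 values shown sits, so compound 2 sits at the edge of what the assay can report. Compound 3 `COc1ccc(-n2ccc(=O)c(C(=O)Nc3ccc(Oc4ccnc5c4ccn5C)cc3)n2)cc1` is the next candidate. It differs from compound 2 in one place: methoxy in place of chloro on an aromatic carbon. Within the data shown here, no measured step between two compounds is available; the only guide is that compound 1, carrying the 4-methoxyphenyl, and compound 2, carrying the 4-chlorophenyl, both sit at the very weak end. The step of an at least 1.0-fold lower number from compound 2 to compound 3 (0.01 log units; that floor lies within the scatter) is expected to stay within the scatter. Compound 3 is therefore expected to give about 58000 nM, with a range from 30000 nM to 150000 nM, and a fair chance that only a limit is reported again.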

Compound 3, half-maximal inhibitory concentration: > 60000 nM
Compound 3 ended at the assay's limit; the forecaster's own chance of this, stated with the estimate: 50%; middle value at least 1.0-fold (0.01 log units) from the limit.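

With both compound 2 and compound 3 at a limit of the assay, the step from 4-chlorophenyl to 4-methoxyphenyl cannot be read, and neither group brings a measured number at this position in this assay. The new compound also links the methoxy pair: methyl in place of hydrogen on an aromatic nitrogen gives an at least 1.1-fold higher number from compound 1 to compound 3 (0.05 log units; that floor lies within the scatter), so that step can be given only as a floor, which does not separate the two compounds. The series now crowds against the edge of what the assay can report: the limit of > 60000 nM in this assay, at which 2 of the 3 values shown sit.

As far as these compounds go, whether an amine or a carboxylic acid on this aromatic carbon would give a number clear of the limit remains open. From the compounds shown here alone, the true size of the methyl step also stays unknown, as does any real difference between chloro and methoxy.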